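Swapping a bromophenyl sulfonyl for a tolyl sulfonyl

This account rests on a few compounds, and the source may have more. Where it says the series, first, only, none or still open, it means among the compounds named here.

Compound 1, `CCOC(=O)c1oc2ccc(N(Cc3ccccc3)S(=O)(=O)c3cccc(Br)c3)cc2c1C`, in a functional assay on HCT-116 cells (Homo sapiens) for inhibition, read by MTT assay, with a stated time of 72 h (on this read-out higher numbers stand for weaker inhibition and lower numbers for stronger inhibition), gives > 40000 nM, which is a limit of the assay.
Compound 2, `CCOC(=O)c1oc2ccc(N(Cc3ccccc3)S(=O)(=O)c3ccccc3Br)cc2c1C`, in this assay gives > 40000 nM, again a limit.

Compound 2 therefore stands at a limit rather than at a number, and both values shown sit at that same limit, as the limit of > 40000 nM in this assay, at which 2 of the 2 values shown sit, records. Within the data shown here, the single measured step, a step that the two limits leave unreadable from compound 1 to compound 2, is unreadable on these grounds. Compound 3, `CCOC(=O)c1oc2ccc(N(Cc3ccccc3)S(=O)(=O)c3ccc(C)cc3)cc2c1C`, differs from compound 2 by 4-methylphenyl in place of 2-bromophenyl on a sulfonyl sulfur. No measured step bears readably on this change; the only evidence is the limit of > 40000 nM in this assay, at which 2 of the 2 values shown sit, which places every shown value at the limit. Compound 3 is accordingly expected to stay at or near that limit. The step expected in this assay is a step that the limit leaves unreadable from compound 2 to compound 3, which is no change beyond the scatter. Compound 3 is estimated at 50000 nM, within a range from 15000 nM to 200000 nM.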

Compound 3, half-maximal inhibitory concentration: > 40000 nM
Compound 3: no number, only a limit; the forecaster's own chance of this, stated with the estimate: 80%; the middle value is on the limit's open side.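

In this assay compound 3 gives > 40000 nM, which is a limit. Among these compounds, no step among compound 1, compound 2 and compound 3 can be read: the limit of > 40000 nM in this assay, at which 3 of the 3 values shown sit. The compounds shown leave open whether 2-bromophenyl, 3-bromophenyl and 4-methylphenyl on the sulfonyl sulfur differ at all.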